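Benzoxazole in Place of Chlorophenyl on the Pendant Ring

The source may report more compounds than this note shows. Statements on the series, on what has been measured and on what is new or still open speak of the compounds shown alone.

Compound 2 `O=C(O)c1csc(SCCN2C(=O)CC[C@@H]2/C=C/[C@@H](O)Cc2cccc(-c3ccc(Cl)cc3)c2)n1` stands lowest of the three compounds measured in a functional assay on CHO cells for agonist activity at prostaglandin E2 receptor EP2 subtype (Rattus norvegicus), read by cAMP accumulation and immunoassay, with a stated time of 10 min (a lower number here means that less compound is needed, a higher number that more compound is needed for the effect), where compound 2 gives 260 nM. Compound 1 `O=C(O)c1csc(SCCN2C(=O)CC[C@@H]2/C=C/[C@@H](O)Cc2cccc(-c3ccccc3)c2)n1`, which carries a plain phenyl at the same position, gives 1800 nM in this assay, and compound 3 `Cc1cccc2oc(-c3cccc(C[C@H](O)/C=C/[C@H]4CCC(=O)N4CCSc4nc(C(=O)O)cs4)c3)nc12`, which carries a 4-methyl-1,3-benzoxazol-2-yl there, gives 8500 nM. The steps among them are all beyond the scatter: a 6.9-fold lower number from compound 1 to compound 2 (0.84 log units; beyond the scatter), a 4.7-fold higher number from compound 1 to compound 3 (0.67 log units; beyond the scatter) and, most relevant here, a 33-fold higher number from compound 2 to compound 3 (1.51 log units; beyond the scatter).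

Compound 4 `Cc1cc(C)c2oc(-c3cccc(C[C@H](O)/C=C/[C@H]4CCC(=O)N4CCSc4nc(C(=O)O)cs4)c3)nc2c1` differs from compound 2 by the change (5,7-dimethyl-1,3-benzoxazol-2-yl in place of 4-chlorophenyl on an aromatic carbon). This is the same kind of exchange as the step from compound 2 to compound 3, a chlorophenyl giving way to a methyl-bearing benzoxazolyl, with the methyl count and pattern on the benzoxazole the only point of difference between compound 3 and compound 4. Among the measured compounds shown here, no measured step separates the effect of one or two methyls on the benzoxazole, so compound 3 is the closest guide. A large rise in the number is therefore expected for compound 4, with a 23-fold higher number from compound 2 to compound 4 (1.36 log units; beyond the scatter) as the estimated step. Compound 4 is expected to give about 6000 nM in this assay, with a range from 1500 nM to 25000 nM.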

Compound 4, half-maximal effective concentration: > 10000 nM
Compound 4: no number, only a limit (the forecaster's own chance of this, stated with the estimate: 15%); middle value at least 1.6-fold (0.22 log units) from the limit.
By their numbers in this assay, from the lowest: compound 2; then compound 1; then compound 3. At a limit, above all of these: compound 4.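

Compound 4 gives no number in this assay, and > 10000 nM is a limit of the assay: the limit of > 10000 nM in this assay, at which 1 of the 4 values shown sits.

Even so, the exchange at this position can be read as an at least 38-fold higher number from compound 2 to compound 4 (1.58 log units; beyond the scatter), and measured against the plain phenyl it is an at least 5.5-fold higher number from compound 1 to compound 4 (0.74 log units; beyond the scatter), so among the four compounds shown, both benzoxazolyl groups give higher numbers than the phenyl and the 4-chlorophenyl, with no compound going against this. Among the compounds shown here, the comparison between the two benzoxazolyl groups is an at least 1.1-fold higher number from compound 3 to compound 4 (0.07 log units; that floor lies within the scatter), which means that the 5,7-dimethyl pattern cannot be placed relative to the single 4-methyl group, and the extra methyl has no readable effect here.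

The compounds shown leave open whether the benzoxazolyl ring itself or its methyl groups account for the higher numbers, a question that the unsubstituted 1,3-benzoxazol-2-yl would address. They also leave open whether a chloro on the benzoxazolyl ring, in place of methyl, would bring the number back towards that of compound 2, as chloro does on the phenyl ring.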